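This account rests on a few compounds, and the source may have more. Where it says the series, first, only, none or still open, it means among the compounds named here.

Working notes on the series. Two compounds of the shared core have numbers in a functional assay on NALM-6 cells (Homo sapiens) for inhibition, read by MTT assay, with a stated time of 48 h (on this read-out lower numbers stand for stronger inhibition and higher numbers for weaker inhibition), so far. Compound 1 `C=C1C(=O)N(c2ccccc2)N(c2ccccc2)C1c1ccccc1` carries three phenyl groups; in this assay compound 1 gives 3820 nM. Compound 2 `C=C1C(=O)N(c2ccccc2)N(C)C1c1ccc(OC)cc1` has a methyl on one ring nitrogen and a methoxy group on the pendant aromatic ring; in this assay compound 2 gives 49300 nM, the highest of the two numbers shown, and its gap to compound 1 lies beyond the scatter. Since compound 2 and compound 1 differ in more than one place, no single change can be read from that gap.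

Compound 3 `C=C1C(=O)N(c2ccccc2)N(C)C1c1ccccc1` is not yet measured. It differs from compound 2 by hydrogen in place of methoxy on an aromatic carbon, leaving the methyl on the ring nitrogen in place. Within the data shown here, no measured pair shows this change on its own, so the expected size of the step rests only on the fact that compound 3 moves partway back toward compound 1 in structure. A modest shift toward a lower number, or none beyond the scatter, is expected; the estimated step is a 2.5-fold lower number from compound 2 to compound 3 (0.39 log units; beyond the scatter). For compound 3 the estimate is 20000 nM, with a range from 5000 nM to 60000 nM.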

Compound 3, half-maximal inhibitory concentration: 24400 nM
Beside the measured number, compound 3's estimate is 1.2-fold (0.09 log units) below it; the measured number falls inside the stated range.
By their numbers in this assay, from the lowest: compound 1; then compound 3; then compound 2.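

With compound 3 in hand, the gap between compound 1 and compound 2 can now be read as two single changes, each with its own step in this assay. Hydrogen in place of methoxy on an aromatic carbon, para to a large group, gives a 2.0-fold lower number from compound 2 to compound 3 (0.31 log units; beyond the scatter), so the methoxy group at this place goes with a higher number when a methyl sits on the ring nitrogen, while methyl in place of phenyl on an amine nitrogen in a ring gives a 6.4-fold higher number from compound 1 to compound 3 (0.81 log units; beyond the scatter), the larger of the two steps, and both steps lie beyond the scatter. No measurement in hand accounts for either step.

From the compounds shown here alone, the methoxy step is known only with a methyl on the ring nitrogen, so whether it keeps its size and direction with a phenyl there remains open. Also open, going by these compounds, is how a fluorine, a hydroxyl group or an amine at the same aromatic carbon would compare with hydrogen and methoxy, and whether an ethyl or a benzyl group on the ring nitrogen would fall between methyl and phenyl.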